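The source may hold more compounds than are shown below. What is called first, only, known or untested is meant among the compounds shown, and "the series" means these compounds.

Compound 1 `COc1ccccc1N1CCN(CCn2c(=O)[nH]c3cc[nH]c3c2=O)CC1` and compound 2 `O=c1[nH]c2cc[nH]c2c(=O)n1CCN1CCN(c2ccccc2Cl)CC1` share one core, and in an assay for binding affinity to Adrenergic receptor alpha-1 (Rattus norvegicus) (on this read-out lower numbers stand for stronger inhibition and higher numbers for weaker inhibition), compound 1 gives 2.31 nM while compound 2 gives 0.94 nM. Among the measured compounds shown here, the single change between them, (chloro in place of methoxy on an aromatic carbon), made a 2.5-fold lower number from compound 1 to compound 2 (0.39 log units; beyond the scatter). Compound 3 `COc1ccccc1N1CCN(CCCn2c(=O)[nH]c3cc(-c4ccc(C)cc4)[nH]c3c2=O)CC1` rests on another core; how it differs from the core of compound 1 is not broken down here. In this assay compound 3 gives 47.9 nM, the highest number among the three measured compounds. Compound 4 `Cc1ccc(-c2cc3[nH]c(=O)n(CCCN4CCN(c5ccccc5Cl)CC4)c(=O)c3[nH]2)cc1` carries the same change on the core of compound 3: chloro in place of methoxy on an aromatic carbon. The place of the change is described in the same words in both pairs, so it counts as the same change. A step of similar size is expected here, because the earlier step of a 2.5-fold lower number from compound 1 to compound 2 (0.39 log units; beyond the scatter) was modest. The expected step is a 2.5-fold lower number from compound 3 to compound 4 (0.40 log units; beyond the scatter). Compound 4 is therefore estimated at 19 nM in this assay, most likely falling between 8 nM and 45 nM.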

Compound 4, inhibition constant: 110 nM
Compound 4: the middle estimate sits 5.8-fold (0.76 log units) below what was measured; the whole stated range lies below it.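

In this assay, replacing 2-methoxyphenyl with 2-chlorophenyl gave a 2.3-fold higher number from compound 3 to compound 4 (0.36 log units; beyond the scatter), which runs opposite to the earlier step. The same change therefore behaves differently on the two cores: the same change on two cores in this assay, a 2.5-fold lower number (0.39 log units; beyond the scatter) from compound 1 to compound 2 and a 2.3-fold higher number (0.36 log units; beyond the scatter) from compound 3 to compound 4, 5.6-fold (0.75 log units) apart, beyond the scatter of two such steps

This shows that the effect of the change on one core cannot simply be carried over to the other in this series. It does not show why the direction reverses, and two pairs cannot establish a rule for other cores.

The compounds shown leave open which part of the difference between the two cores goes with the reversal. On these data alone, it also remains open how a fluoro group in place of methoxy would behave on each core.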